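A few compounds are considered here, and "the series" means these few. Any claim that something is new, unique, unknown or untested is made for them only; others in the source may bear on it.

Measured so far:
compound 1 `C/C(=N\NC(=O)c1ccncc1)C(=O)Nc1ccc(OC(F)(F)F)cc1` — > 50000 nM in a functional assay on HepG2 cells (Homo sapiens) for cytotoxicity, read by MTT assay, with a stated time of 72 h (a lower number here means a stronger inhibitor, a higher number a weaker inhibitor), a limit of the assay
compound 2 `C/C(=N\NC(=O)c1ccncc1)C(=O)Nc1ccc(Cl)cc1` — > 50000 nM in this assay, a limit of the assay

Both values are limits, so the step that the two limits leave unreadable from compound 1 to compound 2 cannot be read because of the limit of > 50000 nM in this assay, at which 2 of the 2 values shown sit. Compound 2 therefore stands at the limit of this assay with no number of its own, and it is not ordered against compound 1.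

Compound 3 `C/C(=N\NC(=O)c1ccncc1)C(=O)Nc1ccc(Br)cc1` differs from compound 2 by bromo in place of chloro on an aromatic carbon. For the measured compounds named here, no measured step bears on this change; the one available step gives no size. With both measured compounds at the limit, compound 3 is expected to remain there as well. The expected step that the limit leaves unreadable from compound 2 to compound 3 is thus none beyond the scatter, and a limit rather than a number is the likely report. Compound 3 is estimated at 80000 nM, in a range from 40000 nM to 200000 nM.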

Compound 3, half-maximal inhibitory concentration: > 50000 nM
Compound 3: no number, only a limit; the forecaster's own chance of this, stated with the estimate: 85%; the middle value does not contradict the limit.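

For the compounds shown here, no step among compound 1, compound 2 and compound 3 can be read in this assay, because each gives only a limit of the assay: the limit of > 50000 nM in this assay, at which 3 of the 3 values shown sit.

The compounds shown leave open whether trifluoromethoxy, chloro and bromo differ at all in cytotoxicity, and which change to the shared core would yield a readable number.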